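Ethoxy to butoxy on the shared core: an expected step

The source may hold more compounds than are shown below. What is called first, only, known or untested is meant among the compounds shown, and "the series" means these compounds.

Within the data shown here, compound 1 `CCOc1ccc([C@@H]2CC(=O)c3cc(CC=C(C)C)c(OC)cc3O2)cc1` holds the higher of the two numbers measured so far. In a functional assay on PC-3 cells (Homo sapiens) for inhibition, read by sulforhodamine B assay, with a stated time of 48 h, tested at 50 uM (a higher number here means more inhibition of growth at the concentration tested, a lower number less inhibition of growth), compound 1 gives 60%. Among the measured compounds shown here, compound 2 `C#CCO/N=C1/C[C@@H](c2ccc(OC)cc2)Oc2cc(OC)c(CC=C(C)C)cc21` is the only other measured compound; in this assay compound 2 gives 41%, a value that lies beyond the scatter below that of compound 1. For the measured compounds named here, no two measured compounds differ in a single place, so no step size is known directly from the data.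

Compound 3 `CCCCOc1ccc([C@@H]2CC(=O)c3cc(CC=C(C)C)c(OC)cc3O2)cc1` differs from compound 1 by ethyl in place of hydrogen on a saturated chain carbon, two bonds along the chain from an oxygen on an aromatic ring. Nothing measured shows how lengthening this chain acts on growth inhibition, so the step from compound 1 to compound 3 is expected to stay small, within the scatter, with no clear direction. The step expected here is a number 5 percentage points lower from compound 1 to compound 3 (within the scatter). For compound 3 in this assay the estimate is 55%, within a range from 35% to 75%.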

Compound 3, percent growth inhibition at one concentration: 48%
Compound 3: the middle estimate sits 7 percentage points above what was measured; the measured number falls inside the stated range.
By their numbers in this assay, from the lowest: compounds 2 and 3 (each within the scatter of the next); then compound 1.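

In this assay, among these compounds, this is the first step that can be read directly at this position: ethyl in place of hydrogen on a saturated chain carbon, two bonds along the chain from an oxygen on an aromatic ring, brings a number 12 percentage points lower from compound 1 to compound 3 (beyond the scatter) and gives the first measure of this change on the shared core. The step is modest, but it shows that going from ethoxy to butoxy is not neutral for growth inhibition at the concentration tested. The data offer nothing that explains this loss.

Among the compounds shown here, with only two chain lengths compared, it remains open whether propoxy would lie between them or whether a longer chain, such as hexyloxy, would lower the number further. On these data alone, it is also open how a chain ending in an amine or a carboxylic acid would behave at this position.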